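Adding a Methoxy Group to Compound 2

The source may hold more compounds than are shown below. What is called first, only, known or untested is meant among the compounds shown, and "the series" means these compounds.

In a physicochemical assay for solubility, read by nephelometry, measured as kinetic solubility, at pH 2.0 (a lower number here means a less soluble compound, a higher number a more soluble compound), compound 2 (`Cn1c(-c2ccccc2)cnc1NC(=O)c1ccc(F)cc1`) gives 25 ug/mL. Compound 1 (`COc1ccc(-c2cnc(NC(=O)c3ncc[nH]3)n2C)cc1`) reads > 100 ug/mL, which is a limit of the assay and not a number. Going by the values given here, that leaves compound 2 as the only compound with an actual number, so it is the fixed point for what comes next.

Compound 3 (`COc1ccc(-c2cnc(NC(=O)c3ccc(F)cc3)n2C)cc1`) changes compound 2 in one place. A methoxy group takes the place of a hydrogen on an aromatic carbon, para to a large group, so phenyl becomes 4-methoxyphenyl (methoxy in place of hydrogen on an aromatic carbon).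

Among the compounds with values here, no two measured compounds differ in only one place, so the data offer no direct guide to the size of this change. The cautious expectation in this assay is therefore no step beyond the usual scatter of repeated measurements, with only a slight lean towards a lower number. The estimated change is a 1.3-fold lower number from compound 2 to compound 3 (0.10 log units; within the scatter). For compound 3, the expected value is 20 ug/mL, with an estimated range from 8 ug/mL to 50 ug/mL.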

Compound 3, solubility: 12.5 ug/mL
Compound 3: middle estimate off by 1.6-fold (0.20 log units), on the high side, within the range that was stated.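

In this assay, going by these compounds alone, this is the first direct reading of what a methoxy group does on this aromatic carbon, where it takes the place of hydrogen. The step is a 2.0-fold lower number from compound 2 to compound 3 (0.30 log units; within the scatter), so in this one pair, going from phenyl to 4-methoxyphenyl gives a change that cannot be told apart from the ordinary spread of repeated measurements. Within the data shown here, the other single change, 4-fluorophenyl in place of 1H-imidazol-2-yl on the carbonyl carbon, gives an at least 8.0-fold lower number from compound 1 to compound 3 (0.90 log units; beyond the scatter), which is the only step so far that clears the scatter, and it sits at the carbonyl rather than on the phenyl ring. Compound 1 reads > 100 ug/mL, which is a limit of the assay and not a number: the limit of > 100 ug/mL in this assay, at which 1 of the 3 values shown sits.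

Going by these compounds, it remains open whether another group on the same aromatic carbon, such as an amine or a carboxylic acid, would move the number beyond the scatter. On these data alone, it is also open whether methoxy in place of hydrogen gives a similar step when 1H-imidazol-2-yl, rather than 4-fluorophenyl, sits on the carbonyl carbon.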